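The source may report more compounds than this note shows. Statements on the series, on what has been measured and on what is new or still open speak of the compounds shown alone.

In a functional assay on PC-3 cells (Homo sapiens) for cytotoxicity, read by MTT assay, with a stated time of 72 h (a higher number here means that more compound is tolerated, a lower number that less compound is tolerated), three compounds of this family have been measured, all built on the same core in which two acyl groups flank a carbon double-bonded to nitrogen. Compound 1 `C[Se]/C(=N\C(=O)c1cc2ccccc2s1)NC(=O)c1cc2ccccc2s1` gives 94000 nM. Compound 2 `CS/C(=N\C(=O)c1csc([N+](=O)[O-])c1)NC(=O)c1csc([N+](=O)[O-])c1` reaches only the limit of the assay, at > 100000 nM. Compound 3 `C[Se]/C(=N\C(=O)c1ccco1)NC(=O)c1ccco1` likewise gives only a limit, at > 100000 nM. Compound 3 therefore stands at the edge of what this assay can resolve, and it shares that position with one other compound, as shown by the limit of > 100000 nM in this assay, at which 2 of the 3 values shown sit; compound 1 is the only one of the three with a number of its own.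

Compound 4 `CS/C(=N\C(=O)c1ccco1)NC(=O)c1ccco1` differs from compound 3 in a single place: a group of 2 heavy atoms (1 carbon, 1 sulfur; no ring) in place of a group of 2 heavy atoms (1 carbon, 1 selenium; no ring), on a carbon with a double bond to nitrogen. Going by the values given here, no step between two measured compounds is available for this exchange, so nothing here ties the selenium-to-sulfur swap to any shift in tolerated concentration. Compound 2 carries the methylsulfanyl group and also sits at the limit, but it differs from compound 3 in its acyl groups as well, so it offers no clean comparison.

The expected step from compound 3 to compound 4 in this assay is a step that the limit leaves unreadable from compound 3 to compound 4, that is, none beyond the usual scatter. Compound 4 is accordingly estimated at 110000 nM, with a range from 45000 nM to 300000 nM, and most likely this assay will again report only a limit.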

Compound 4, concentration lethal to 50% of the cells: > 100000 nM
Compound 4 gave a limit, no number (the forecaster's own chance of this, stated with the estimate: 70%); the middle value does not contradict the limit.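

In this assay compound 4 gives > 100000 nM, a limit and not a number. Compound 3 gives > 100000 nM, likewise a limit, so no step can be read from compound 3 to compound 4. The compounds shown leave open whether replacing the selenium-bearing group with methylsulfanyl shifts the tolerated concentration at all: the limit of > 100000 nM in this assay, at which 3 of the 4 values shown sit.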